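A few compounds are considered here, and "the series" means these few. Any claim that something is new, unique, unknown or untested is made for them only; others in the source may bear on it.

Compound 1 `Nc1nc(N)c2cc(N(Cc3ccc(OC(F)(F)F)cc3)Cc3ccc(OC(F)(F)F)cc3)ccc2n1`: > 200000 nM
Compound 2 `Nc1nc(N)c2cc(NCc3ccc4c(c3)OCCO4)ccc2n1`: > 200000 nM
Compound 3 `COc1ccc(CN(Cc2ccc(OC)cc2)c2ccc3nc(N)nc(N)c3c2)cc1`: > 200000 nM

In an ADME assay on Vero cells (Chlorocebus sabaeus) for cytotoxicity, read by MTT assay, with a stated time of 24 h (on this read-out lower numbers stand for higher toxicity in this test and higher numbers for lower toxicity in this test), compound 1 gives > 200000 nM, which is a limit of the assay and not a number. Compound 2 and compound 3 also stop at a limit, so compound 1 cannot be ranked against either of them. The whole set stands at the limit of > 200000 nM in this assay, at which 3 of the 3 values shown sit. Within the data shown here, no measured pair of compounds differing in one place is available to give the size of a single change.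

Compound 4 `CCN(Cc1ccc(OC(F)(F)F)cc1)c1ccc2nc(N)nc(N)c2c1` has not yet been measured. It differs from compound 1 by methyl in place of 4-(trifluoromethoxy)phenyl on a saturated chain carbon bound to a nitrogen on an aromatic ring, which is the same as 4-(trifluoromethoxy)benzyl to ethyl: methyl in place of 4-(trifluoromethoxy)phenyl on a saturated chain carbon bound to a nitrogen on an aromatic ring. Given (the limit of > 200000 nM in this assay, at which 3 of the 3 values shown sit), no step beyond the usual scatter is expected in this assay, in either direction, and the reading may well be a limit again. The expected change is a number no higher from compound 1 to compound 4 (the limit leaves the size open). For compound 4 the estimated value is 200000 nM, with an expected range from 80000 nM to 400000 nM.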

Compound 4, half-maximal cytotoxic concentration in the Vero assay: > 200000 nM
Compound 4 gave a limit, no number; the forecaster's own chance of this, stated with the estimate: 75%; the middle value lies on the limit itself.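

In the Vero assay compound 4 gives > 200000 nM, which is a limit of the assay and not a number. Compound 1 also stops at a limit there, so no step can be read from compound 1 to compound 4. The compounds shown leave open what numerical half-maximal cytotoxic concentration any of them has, and how the change from 4-(trifluoromethoxy)benzyl to ethyl affects it. In a physicochemical assay for inhibition, read by spectrophotometry, with a stated time of 10 min (on this read-out higher numbers stand for weaker inhibition and lower numbers for stronger inhibition), compound 1 gives 33900 nM and compound 4 gives 7360 nM. In the physicochemical assay the change from 4-(trifluoromethoxy)benzyl to ethyl gives a 4.6-fold lower number from compound 1 to compound 4 (0.66 log units; beyond the scatter).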